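Chain length and a hydroxamate: extending compound 3

The source may hold more compounds than are shown below. What is called first, only, known or untested is meant among the compounds shown, and "the series" means these compounds.

Four compounds share a propargyl-bearing benzylamine linked through an anilide to a chain that ends in a hydroxamic acid. Compound 1 `C#CCN(C)Cc1cccc(NC(=O)CCCCCCC(=O)NO)c1` and compound 2 `C#CCN(C)Cc1cccc(NC(=O)CCCCCCCC(=O)NO)c1` carry the anilide on one position of the ring; compound 3 `C#CCN(C)Cc1ccc(NC(=O)CCCCC(=O)NO)cc1` and the not yet measured compound 4 `C#CCN(C)Cc1ccc(NC(=O)CCCCCC(=O)NO)cc1` carry it on another, and the difference between the two cores is not broken down here.

In a functional assay on PC-3 cells (Homo sapiens) for inhibition, read by MTT assay, with a stated time of 48 h (a higher number here means a weaker inhibitor of growth, a lower number a stronger inhibitor of growth), compound 1 gives 330 nM. Compound 2, with (hydroxycarbamoyl)methyl in place of hydroxycarbamoyl on a saturated chain carbon, six bonds along the chain from a carbonyl carbon, gives 4070 nM in this assay. That single added chain carbon gives a 12-fold higher number from compound 1 to compound 2 (1.09 log units; beyond the scatter).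

For compound 3 only a limit is known in this assay: the value > 10000 nM marks the edge of what the assay reports, not a number (the limit of > 10000 nM in this assay, at which 1 of the 3 values shown sits).

Compound 4 arises from compound 3 by (hydroxycarbamoyl)methyl in place of hydroxycarbamoyl on a saturated chain carbon, four bonds along the chain from a carbonyl carbon. This is the same kind of change as that from compound 1 to compound 2, but not the same: there the place is six bonds along the chain from a carbonyl carbon, here it is four bonds along. Compound 3 starts from a limit rather than a number, so the step cannot be read directly from the pair of compound 1 and compound 2. The chain of compound 4 comes closer to that of compound 1, which gives 330 nM, yet remains shorter. For compound 4 the expectation is therefore that the step is an at least 1.4-fold lower number from compound 3 to compound 4 (0.15 log units; that floor lies within the scatter). Compound 4 is estimated at 7000 nM, with a range from 1500 nM to 30000 nM, and a real chance that the assay again returns only a limit.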

Compound 4, concentration for 50% growth inhibition: > 10000 nM
Compound 4 was reported as a limit; the forecaster's own chance of this, stated with the estimate: 45%; at least 1.4-fold (0.15 log units) between middle value and limit.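

In this assay compound 4 gives > 10000 nM, a limit and not a number, just as compound 3 does. No step from compound 3 to compound 4 can therefore be read: the limit of > 10000 nM in this assay, at which 2 of the 4 values shown sit.

The compounds shown leave open how strongly compound 3 and compound 4 actually inhibit growth, and whether lengthening the chain on their core matters as much as it does between compound 1 and compound 2.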